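The source may hold more compounds than are shown below. What is called first, only, known or untested is meant among the compounds shown, and "the series" means these compounds.

Compound 1 `COc1cc(C2CC(c3ccc(OCc4cn(Cc5ccc([N+](=O)[O-])cc5)nn4)cc3)=NN2C(C)=O)ccc1Oc1cn(Cc2ccc([N+](=O)[O-])cc2)nn1`: 27%
Compound 2 `COc1ccc(C2CC(c3ccc(OCc4cn(Cc5ccc([N+](=O)[O-])cc5)nn4)cc3)=NN2C(C)=O)cc1`: 4%
Compound 3 `COc1cc(C2CC(c3ccc([N+](=O)[O-])cc3)=NN2C(C)=O)ccc1OCc1cn(Cc2ccc([N+](=O)[O-])cc2)nn1`: 33%

These three compounds were tested in a functional assay on COLO 205 cells (Homo sapiens) for inhibition, read by sulforhodamine B assay, tested at 10 uM; a higher number here means more inhibition of growth at the concentration tested, a lower number less inhibition of growth. Compound 3 holds the highest of the three numbers; compound 1 sits within the usual scatter of it, while compound 2 lies beyond the scatter, well below. Compound 4 `COc1cc(C2CC(c3cc(OC)c(OC)c(OC)c3)=NN2C(C)=O)ccc1OCc1cn(Cc2ccc([N+](=O)[O-])cc2)nn1` is built from compound 3 by one change: 3,4,5-trimethoxyphenyl in place of 4-nitrophenyl on a carbon with a double bond to nitrogen. Within the data shown here, no pair of measured compounds isolates such a change, so there is nothing to read the size of the step from. The expected step from compound 3 to compound 4 in this assay is a number 3 percentage points lower from compound 3 to compound 4 (within the scatter), which is no more than the scatter in either direction. Compound 4 is therefore estimated at 30%, within a range of 8% to 55%.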

Compound 4, percent growth inhibition at one concentration: 60%
Compound 4: middle estimate off by 30 percentage points, on the low side, outside the stated range (above it).
By their numbers in this assay, from the lowest: compound 2; then compounds 1 and 3 (each within the scatter of the next); then compound 4.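

Moving to 3,4,5-trimethoxyphenyl in place of 4-nitrophenyl on the carbon with a double bond to nitrogen gives, in this assay, a number 27 percentage points higher from compound 3 to compound 4 (beyond the scatter), the first single-place comparison at this position. The earlier compounds shown here could not show that this position responds to its aryl group, and here the response is beyond the scatter. Nothing available explains the step.

Going by these compounds, whether all three methoxy groups are needed remains open. So does how an amine or a carboxylic acid on that phenyl ring would read out.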